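Alkylamine Chain Variation and Beta-Galactosidase Inhibition

The compounds below may be only part of what the source reports. "The series", "measured", "known", "first", "only" and "open" are said of these compounds alone.

Compound 1, `CCCCN[C@@H]1C=C[C@H](O)[C@H](O)[C@H]1O`, in an assay for inhibition of beta-galactosidase (Homo sapiens), read by fluorescence, with a stated time of 30 min, at pH 4.5 (on this read-out higher numbers stand for weaker inhibition and lower numbers for stronger inhibition), gives 50000 nM.
Compound 2, `CCCCCCN[C@@H]1C=C[C@H](O)[C@H](O)[C@H]1O`, in this assay gives 56000 nM.

Compound 2 carries the higher of the two measured numbers, but the step of a 1.1-fold higher number from compound 1 to compound 2 (0.05 log units; within the scatter) leaves the two compounds indistinguishable within the scatter. Compound 3, `CC(C)CN[C@@H]1C=C[C@H](O)[C@H](O)[C@H]1O`, differs from compound 2 by isopropyl in place of pentyl on a saturated chain carbon bound to an amine nitrogen. Within the data shown here, the only measured step that bears on this change, a 1.1-fold higher number from compound 1 to compound 2 (0.05 log units; within the scatter), also altered the chain on the amine nitrogen and produced nothing beyond the scatter. Compound 3 is therefore expected to show a step of a 1.1-fold lower number from compound 2 to compound 3 (0.05 log units; within the scatter), none beyond the scatter. Compound 3 is estimated at 50000 nM, with a range from 25000 nM to 100000 nM.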

Compound 3, half-maximal inhibitory concentration: 41000 nM
The estimate for compound 3 lay 1.2-fold (0.09 log units) above the measured number; measured number inside the range.
By their numbers in this assay, from the lowest: compounds 3, 1 and 2 (each within the scatter of the next).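

In this assay, isopropyl in place of pentyl on a saturated chain carbon bound to an amine nitrogen gave a 1.4-fold lower number from compound 2 to compound 3 (0.14 log units; within the scatter), and isopropyl in place of propyl at that place gave a 1.2-fold lower number from compound 1 to compound 3 (0.09 log units; within the scatter). The earlier compounds shown here showed only a change of chain length, whereas these steps show that a branched chain at this place also stays within the scatter of both unbranched chains. No measurement bearing on the reason for this result is available. As far as these compounds go, whether a phenyl ring, a carboxylic acid or a much longer chain at this place would produce a step beyond the scatter remains open.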